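This account rests on a few compounds, and the source may have more. Where it says the series, first, only, none or still open, it means among the compounds named here.

Measured so far:
Compound 1, `C=C1C(=O)O[C@@H]2[C@@H]1[C@H](OC(=O)C(C)C)C(=O)[C@@H](C)C[C@H](O)C[C@](C)(O)[C@H]2OC(=O)/C(C)=C\C`: 1.6 ug/mL
Compound 2, `C=C1C(=O)O[C@@H]2[C@@H]1[C@H](OC(=O)C(C)C)C(=O)[C@@H](C)C[C@H](O)C[C@](C)(O)[C@H]2OC(=O)C(C)C`: 3.78 ug/mL

For the measured compounds named here, of these two numbers in a functional assay on SK-OV-3 cells (Homo sapiens) for cytotoxicity, read by sulforhodamine B assay (a lower number here means that less compound is needed, a higher number that more compound is needed for the effect), compound 2 holds the higher one; the gap to its only neighbour is a 2.4-fold higher number from compound 1 to compound 2 (0.37 log units; beyond the scatter). Compound 3, `C=C1C(=O)O[C@@H]2[C@@H]1[C@H](OC(=O)C(C)CC)C(=O)[C@@H](C)C[C@H](O)C[C@](C)(O)[C@H]2OC(=O)C(C)C`, is not yet measured. It differs from compound 2 by methyl in place of hydrogen on a saturated chain carbon, two bonds along the chain from a carbonyl carbon. Going by the values given here, the only measured step, a 2.4-fold higher number from compound 1 to compound 2 (0.37 log units; beyond the scatter), concerns a different change on a carbonyl carbon and so bears only loosely here. For this change a step of a 1.1-fold higher number from compound 2 to compound 3 (0.02 log units; within the scatter) is expected, a step within the usual scatter. Compound 3 is therefore expected to give about 4 ug/mL in this assay, between 2 ug/mL and 8 ug/mL.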

Compound 3, concentration for half-maximal effect: 2.24 ug/mL
Compound 3: middle estimate off by 1.8-fold (0.25 log units), on the high side; the range from low to high includes it.
By their numbers in this assay, from the lowest: compounds 1, 3 and 2 (each within the scatter of the next, the first and the last beyond it).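

In this assay, for the compounds shown here, isopropyl to sec-butyl gives a 1.7-fold lower number from compound 2 to compound 3 (0.23 log units; within the scatter), the first reading at this saturated chain carbon, two bonds along the chain from a carbonyl carbon. The position therefore accepts this added methyl without a change that stands out from assay scatter. No measurement shown offers an explanation for this result. On these data alone, whether a longer chain, a phenyl ring or an amine would be accepted here remains open. So does whether the same methyl would behave alike on compound 1 .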